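A few compounds are considered here, and "the series" means these few. Any claim that something is new, unique, unknown or untested is made for them only; others in the source may bear on it.

Working notes on the series.

Compound 1 `CCOC(=O)CCCCCOC(COCc1ccc(OC)cc1)Cn1ccnc1` carries an ethoxycarbonyl ester at the end of the chain. In a functional assay on a cell-free system (plasma) for inhibition of Thromboxane-A synthase (Homo sapiens) (a higher number here means a weaker inhibitor, a lower number a stronger inhibitor), compound 1 gives 120 nM. Compound 2 `COc1ccc(COCC(Cn2ccnc2)OCCCCCCC(=O)O)cc1` is the corresponding free acid; in this assay compound 2 gives 1890 nM. Within the data shown here, of the two numbers measured so far, compound 1 stands lowest, with compound 2 nearest to it at a 16-fold higher number from compound 1 to compound 2 (1.20 log units; beyond the scatter).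

Compound 3 `CCOC(=O)/C=C/CCCOC(COCc1ccc(OC)cc1)Cn1ccnc1` is not yet measured in this assay. Its change from compound 1 is 2-(ethoxycarbonyl)ethenyl in place of 2-(ethoxycarbonyl)ethyl on a saturated chain carbon, three bonds along the chain from an oxygen on a saturated carbon. Among the measured compounds shown here, the ester end of the chain is kept in this change, so the only measured step, which concerns the ester-to-acid exchange from compound 1 to compound 2, does not bear on it directly; no step among the measured compounds shows the effect of a double bond in the chain. With the ester retained and the chain of the same length, no step beyond the scatter is expected in this assay, in either direction, and the estimate for compound 3 is therefore close to compound 1, with a wide range to reflect the absent precedent.

Compound 3 is expected at 150 nM (range 50 nM to 450 nM), that is an estimated step of a 1.3-fold higher number from compound 1 to compound 3 (0.10 log units; within the scatter).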

Compound 3, half-maximal inhibitory concentration: 10000 nM
Compound 3: the middle estimate sits 67-fold (1.82 log units) below what was measured; measured number above the stated range.
By their numbers in this assay, from the lowest: compound 1; then compound 2; then compound 3.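

In this assay, the exchange of 2-(ethoxycarbonyl)ethyl for 2-(ethoxycarbonyl)ethenyl gives an 83-fold higher number from compound 1 to compound 3 (1.92 log units; beyond the scatter), so this place, three bonds along the chain from an oxygen on a saturated carbon, does not tolerate the added double bond, even with the ester end and the chain length kept. The comparison with the free acid gives a 5.3-fold higher number from compound 2 to compound 3 (0.72 log units; beyond the scatter), so within these compounds the ester end does not by itself hold the number low: it does so in compound 1 with the saturated chain, but not in compound 3 with the unsaturated one. Nothing in the available data bears on what lies behind this step.

The compounds shown leave open whether a carboxylic acid in place of the ethyl ester on the unsaturated chain of compound 3 would give a number like that of compound 2 or a still higher one. Also open, on these data alone, is whether the step belongs to this place and this geometry of the double bond, which a cis double bond, a triple bond or a double bond further along a longer chain would help to settle.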